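Sulfonamide notes: 4-fluorophenyl to 4-bromo-2-fluorophenyl

The compounds below may be only part of what the source reports. "The series", "measured", "known", "first", "only" and "open" are said of these compounds alone.

In a functional assay on Huh-7 cells (Homo sapiens) for cytotoxicity, read by MTT assay, with a stated time of 72 h (on this read-out lower numbers stand for higher toxicity in this test and higher numbers for lower toxicity in this test), compound 1 `O=S(=O)(CCCCl)N1CCC2(CC1)OOC1(CCCCC1)OO2` gives > 100 ug/mL as a limit of the assay. Compound 2 `O=S(=O)(c1ccc(F)cc1)N1CCC2(CC1)OOC1(CCCCC1)OO2` gives > 100 ug/mL as a limit too, so it stands without a number. Among the measured compounds shown here, the only measured step, a step that the two limits leave unreadable from compound 1 to compound 2, bears on the next change but offers no size to carry forward.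

Compound 3 `O=S(=O)(c1ccc(Br)cc1F)N1CCC2(CC1)OOC1(CCCCC1)OO2` carries 4-bromo-2-fluorophenyl in place of 4-fluorophenyl on a sulfonyl sulfur.

No step beyond the scatter and no direction is expected in this assay because of the limit of > 100 ug/mL in this assay, at which 2 of the 2 values shown sit, and the absence of any numerical reading in the series. The expected step is a step that the limit leaves unreadable from compound 2 to compound 3 and that size is only an estimate. Compound 3 is estimated at 120 ug/mL with an expected range of 60 ug/mL to 300 ug/mL and will probably be reported as a limit again.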

Compound 3, half-maximal cytotoxic concentration: > 100 ug/mL
Compound 3 was reported as a limit (the forecaster's own chance of this, stated with the estimate: 70%); the middle value lies beyond the limit too.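

No step can be read among compound 1, compound 2 and compound 3 in this assay, as each value is a limit and not a number: the limit of > 100 ug/mL in this assay, at which 3 of the 3 values shown sit.

The compounds shown leave open whether any substituent on the sulfonyl sulfur changes the read-out, and by how much.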